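This account rests on a few compounds, and the source may have more. Where it says the series, first, only, none or still open, it means among the compounds named here.

Three compounds of this series carry a measured number in a functional assay on the whole organism for inhibition, with Echinochloa esculenta as the target; a higher number here means a weaker inhibitor, a lower number a stronger inhibitor. Compound 1 `S=c1n(-c2ccc(Br)cc2)c(=S)n2n1CCCC2` gives 66.1 nM, compound 2 `S=c1n(-c2ccc(Cl)cc2)c(=S)n2n1CCCC2` gives 89.1 nM, and compound 3 `COC(=O)CSc1cc(/N=c2\sc(=S)n3n2CCCC3)c(F)cc1Cl` gives 269 nM. Compound 2 thus stands second highest of the three numbers; its nearest neighbour is compound 1, whose value lies within the scatter of it, and the furthest is compound 3, whose number is higher and beyond the scatter. Within the data shown here, the only single-site step measured so far, a 1.3-fold higher number from compound 1 to compound 2 (0.13 log units; within the scatter), exchanges one halogen for another on an aromatic carbon and leaves the number within the scatter.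

Compound 4 `S=c1n(-c2ccccc2)c(=S)n2n1CCCC2` is not yet measured. It differs from compound 2 in that (hydrogen in place of chloro on an aromatic carbon). Among the measured compounds shown here, no measured step removes a halogen from this aromatic carbon outright; the step from compound 1 to compound 2 touches the same kind of group but only swaps bromo for chloro, and it stayed within the scatter. The series therefore gives no firm direction for the change. A modest rise in the number is taken as the more likely outcome, while a change within the scatter remains plausible. Compound 4 is expected to give about 150 nM, with a range from 60 nM to 400 nM. The estimated step is a 1.7-fold higher number from compound 2 to compound 4 (0.23 log units; within the scatter).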

Compound 4, half-maximal inhibitory concentration: 3550 nM
Compound 4: middle estimate off by 24-fold (1.37 log units), on the low side, outside the stated range (above it).
By their numbers in this assay, from the lowest: compounds 1 and 2 (each within the scatter of the next); then compound 3; then compound 4.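

In this assay the aromatic carbon para to a large group turns out to be highly sensitive to losing its halogen: hydrogen in place of chloro gives a 40-fold higher number from compound 2 to compound 4 (1.60 log units; beyond the scatter) and hydrogen in place of bromo gives a 54-fold higher number from compound 1 to compound 4 (1.73 log units; beyond the scatter) against a 1.3-fold higher number from compound 1 to compound 2 (0.13 log units; within the scatter) for the exchange of one halogen for the other. Chloro and bromo are thus interchangeable here within the scatter, whereas having hydrogen at this place is the one change so far with a large effect on the number, and compound 4 now has the highest number of the series. The data on hand offer no explanation for the size of this step.

Still open, from the compounds shown here alone, is whether a methyl, a methoxy or a nitrile at this place would keep the number close to those of compound 1 and compound 2, which would show whether the halogen itself matters or any group other than hydrogen would do. Compound 3 differs from these compounds in more than one place, so it cannot settle this, and a fluoro at this same place on the core of compound 2 would test how far the halogen series holds.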